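A few compounds are considered here, and "the series" means these few. Any claim that something is new, unique, unknown or untested is made for them only; others in the source may bear on it.

Three related compounds have been tested in a functional assay, with a stated time of 30 min; a higher number here means a weaker inhibitor, a lower number a stronger inhibitor. Compound 1, `CCCC/C(C)=N\Nc1nc(-c2cccc([N+](=O)[O-])c2)cs1`, gives 1180000 nM in this assay. Compound 2, `CCC/C(CC)=N\Nc1nc(-c2cccc([N+](=O)[O-])c2)cs1`, gives 1230000 nM. Compound 3, `CCCCC/C(CC)=N\Nc1nc(-c2cccc([N+](=O)[O-])c2)cs1`, gives 1170000 nM. Compound 1 and compound 2 are built from the same atoms joined differently; the difference between their cores is a group of 7 heavy atoms (6 carbon, 1 nitrogen; no ring) in place of a group of 7 heavy atoms (6 carbon, 1 nitrogen; no ring), on a nitrogen on an aromatic ring, and the step between them was a 1.0-fold higher number from compound 1 to compound 2 (0.02 log units; within the scatter). Compound 2 and compound 3 differ by ethyl in place of hydrogen on a saturated chain carbon, three bonds along the chain from a carbon with a double bond to nitrogen, and that step was a 1.1-fold lower number from compound 2 to compound 3 (0.02 log units; within the scatter).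

Compound 4, `CCCCCC/C(C)=N\Nc1nc(-c2cccc([N+](=O)[O-])c2)cs1`, has not yet been measured. It differs from compound 1 by ethyl in place of hydrogen on a saturated chain carbon, four bonds along the chain from a carbon with a double bond to nitrogen. Going by the values given here, this is the same kind of change as the one from compound 2 to compound 3, but not the same one: there the ethyl enters on a saturated chain carbon three bonds along the chain from a carbon with a double bond to nitrogen, whereas in compound 4 it enters four bonds along the chain from a carbon with a double bond to nitrogen. The expected step for compound 4 is a 1.0-fold lower number from compound 1 to compound 4 (0.01 log units; within the scatter) in this assay. This expectation rests on the step of a 1.1-fold lower number from compound 2 to compound 3 (0.02 log units; within the scatter), which stayed within the scatter, and on the fact that all three measured compounds lie within the scatter of one another. The estimate for compound 4 in this assay is therefore 1150000 nM, with a range from 600000 nM to 2300000 nM.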

Compound 4, half-maximal inhibitory concentration: 1150000 nM
Beside the measured number, compound 4's estimate shows no gap at the digits printed; the measured number falls inside the stated range.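

In this assay, ethyl in place of hydrogen on the saturated chain gives a new step of a 1.0-fold lower number from compound 1 to compound 4 (0.01 log units; within the scatter), so the longer chain leaves the number where it was. Set beside the earlier step, the same kind of change behaves alike on both cores, giving no readable shift on either: the same change on two cores in this assay, a 1.1-fold lower number (0.02 log units; within the scatter) from compound 2 to compound 3 and a 1.0-fold lower number (0.01 log units; within the scatter) from compound 1 to compound 4, 1.0-fold (0.01 log units) apart, within the scatter of two such steps

This agreement does not show that the change has a real effect that transfers from one core to another, since two steps that both stay within the scatter can only agree on the absence of a measurable shift, and the ethyl also enters at a different place on the chain in each case, four bonds along it in compound 4 and three bonds along it in compound 3.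

Going by these compounds, whether a much longer chain, or a chain carrying an amine or a carboxylic acid, would move the number beyond the scatter remains open. On these data alone, it is also open whether ethyl in place of hydrogen would stay as silent on a core in which the nitro group gives way to another group, such as a nitrile.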